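Cytotoxicity of Two Piperazine-Linked Triazines and a New Analogue

The compounds below may be only part of what the source reports. "The series", "measured", "known", "first", "only" and "open" are said of these compounds alone.

Measured compounds:
compound 1, `COc1cccc(N2CCN(CC(=O)N3CCN(c4nnc(-c5ccccc5)c(-c5ccccc5)n4)CC3)CC2)c1`, 361000 nM
compound 2, `Cc1ccc(-c2nnc(N3CCN(C(=O)CN4CCN(c5ccccc5Cl)CC4)CC3)nc2-c2ccc(C)cc2)cc1`, only a limit, > 859000 nM

In an ADME assay on NIH3T3 cells (Mus musculus) for cytotoxicity, read by MTT assay, with a stated time of 24 h (a higher number here means a weaker inhibitor, a lower number a stronger inhibitor), compound 1 gives 361000 nM, a weak effect on cell survival. As far as these compounds go, compound 2 gives only a limit in this assay, > 859000 nM, so its true value is unknown beyond that bound; this matches (the limit of > 859000 nM in this assay, at which 1 of the 2 values shown sits). Going by the values given here, no step between measured compounds is available, so nothing about the size of this kind of change can be read from the numbers.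

Compound 3, `COc1ccc(N2CCN(CC(=O)N3CCN(c4nnc(-c5ccc(C)cc5)c(-c5ccc(C)cc5)n4)CC3)CC2)cc1`, differs from compound 2 by 4-methoxyphenyl in place of 2-chlorophenyl on an amine nitrogen in a ring. The change replaces 2-chlorophenyl with 4-methoxyphenyl on the ring amine nitrogen, leaving the rest of the molecule as in compound 2. Since compound 2 sits at a limit, any expectation for compound 3 is uncertain: a move either way within the scatter, or no move at all, is plausible. Compound 3 is expected to remain a weak inhibitor in this assay, estimated at 600000 nM with a range from 250000 nM to 2000000 nM, and the expected step is an at least 1.4-fold lower number from compound 2 to compound 3 (0.15 log units; that floor lies within the scatter); a limit rather than a number is quite likely.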

Compound 3, half-maximal inhibitory concentration: 116000 nM
Beside the measured number, compound 3's estimate is 5.2-fold (0.71 log units) above it; measured number outside the range, below it.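

Putting 4-methoxyphenyl in place of 2-chlorophenyl on the amine nitrogen in the ring gives, in this assay, an at least 7.4-fold lower number from compound 2 to compound 3 (0.86 log units; beyond the scatter). This is the first pair shown that differs in one place, and it establishes that the group on this nitrogen can shift the number beyond the usual scatter, with the lower number here meaning a stronger effect on the cells. The step has only a floor and its true size remains unknown, because the value for compound 2 is a limit and not a number: the limit of > 859000 nM in this assay, at which 1 of the 3 values shown sits.

The swap changes two things at once, the kind of substituent on the phenyl ring (chlorine to methoxy) and where it sits, so this single pair cannot say which of the two accounts for the step. A 4-chlorophenyl or a 2-methoxyphenyl group on the same nitrogen would separate those two changes, while an unsubstituted phenyl would show what the number is with neither substituent present, and a measured number in place of the limit for compound 2 would fix the size of the step.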